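The source may report more compounds than this note shows. Statements on the series, on what has been measured and on what is new or still open speak of the compounds shown alone.

Measured so far:
- Compound 1 `CC(C)=CCOc1cc(Nc2nccs2)ccc1Cl`: 26000 nM
- Compound 2 `CC(C)=CCOc1cc(Nc2nccs2)ccc1C(C)C`: 31000 nM
- Compound 3 `CC(C)=CCOc1cc(Nc2nccs2)ccc1C#N`: 750 nM

In a functional assay on MT2 cells (Homo sapiens) for cytotoxicity, read by MTT assay (a lower number here means that less compound is tolerated, a higher number that more compound is tolerated), compound 1 gives 26000 nM, which places it at the high end of the three numbers, together with compound 2. Compound 4 `CC/C(C)=C\COc1cc(Nc2nccs2)ccc1Cl` differs from compound 1 by methyl in place of hydrogen on a saturated chain carbon bound to a double-bonded chain carbon.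

The measured steps all change a group on an aromatic carbon. Isopropyl in place of chloro gave a 1.2-fold higher number from compound 1 to compound 2 (0.08 log units; within the scatter), cyano in place of chloro gave a 35-fold lower number from compound 1 to compound 3 (1.54 log units; beyond the scatter), and cyano in place of isopropyl gave a 41-fold lower number from compound 2 to compound 3 (1.62 log units; beyond the scatter). None alters the chain, so they guide this change only indirectly. Among the measured compounds shown here, with no measured step at the chain, and only cyano moving the number far, no step beyond the scatter is expected.

The estimated step is a 1.1-fold lower number from compound 1 to compound 4 (0.03 log units; within the scatter).

Compound 4 is expected at 24000 nM, within an estimated range of 9000 nM to 55000 nM.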

Compound 4, half-maximal cytotoxic concentration: 18000 nM
Compound 4: the middle estimate sits 1.3-fold (0.12 log units) above what was measured, within the range that was stated.
By their numbers in this assay, from the lowest: compound 3; then compounds 4, 1 and 2 (each within the scatter of the next).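

Among the compounds shown here, this is the first step at the chain rather than on an aromatic carbon: changing 3-methylbut-2-en-1-yl to 3-methylpent-2-en-1-yl gives a 1.4-fold lower number from compound 1 to compound 4 (0.16 log units; within the scatter) in this assay. At this position, then, one added methyl leaves the number within the usual scatter. No measurement shown here offers an explanation for this result.

On these data alone, whether a much longer chain, or an amine or a carboxylic acid on the chain, would also leave the number unchanged remains open. So does whether the added methyl would behave the same way in compound 3, which carries the cyano group.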